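Allyl series: methylphenyl in place of dichlorophenyl

The source may report more compounds than this note shows. Statements on the series, on what has been measured and on what is new or still open speak of the compounds shown alone.

Measured so far:
compound 1 `C=CCn1c(=O)/c(=C\c2ccc(Cl)c(Cl)c2)[nH]c(=O)/c1=C\c1ccccc1OC`: "not active" (no number reported)
compound 2 `COc1ccccc1/C=c1\c(=O)[nH]/c(=C/c2cccc(Cl)c2Cl)c(=O)n1C`: 200 nM
compound 3 `C=CCn1c(=O)/c(=C\c2ccc(Cl)c(Cl)c2)[nH]c(=O)/c1=C\c1ccccc1`: "not active" (no number reported)

In a functional assay on MCF7 cells (Homo sapiens) for cytotoxicity, read by CCK-8 assay, with a stated time of 72 h (on this read-out higher numbers stand for weaker inhibition and lower numbers for stronger inhibition), compound 1 gives "not active" (no number reported), so no single number stands for it. Compound 3 gives "not active" (no number reported) in this assay, again without a number. Within the data shown here, compound 2 gives 200 nM in this assay, the only numerical value of the three. Among the measured compounds shown here, no pair of measured compounds differs in one place, so no step in this assay has been sized.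

Compound 4 `C=CCn1c(=O)/c(=C\c2cccc(C)c2)[nH]c(=O)/c1=C\c1ccccc1OC` is the next entry. It differs from compound 1 by 3-methylphenyl in place of 3,4-dichlorophenyl on a double-bonded chain carbon bound to an aromatic carbon. For the measured compounds named here, with compound 1 at "not active" (no number reported) there is no number to step from, and no measured step tells the direction. Compound 4 is expected to remain weak, estimated at 20000 nM, within 3000 nM to 100000 nM.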

Compound 4, half-maximal inhibitory concentration: 20700 nM
Beside the measured number, compound 4's estimate is 1.0-fold (0.01 log units) below it; the range from low to high includes it.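

In this assay compound 1 gives "not active" (no number reported) and compound 4 gives 20700 nM and with no number for compound 1 no step can be read between them. The compounds shown leave open how large the effect of 3-methylphenyl in place of 3,4-dichlorophenyl is. No evidence on hand bears on this result.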